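Aryl exchange on the shared core: outlook for compound 4

The compounds below may be only part of what the source reports. "The series", "measured", "known", "first", "only" and "open" are said of these compounds alone.

Measured so far:
compound 1 `O=c1oc2ccc(Cl)cc2c(O)c1C(c1cccc([N+](=O)[O-])c1)c1c(O)c2cc(Cl)ccc2oc1=O` — 27100 nM
compound 2 `COc1cc(C(c2c(O)c3cc(C)ccc3oc2=O)c2c(O)c3cc(C)ccc3oc2=O)cc(OC)c1OC` — 386000 nM
compound 3 `CCOc1cc(C(c2c(O)c3cc(C)ccc3oc2=O)c2c(O)c3cc(C)ccc3oc2=O)ccc1O` — 221000 nM

In an assay on isolated protein for inhibition of Maltase-glucoamylase (Homo sapiens) (on this read-out lower numbers stand for stronger inhibition and higher numbers for weaker inhibition), compound 1 gives the lowest number of the three, with compound 3 nearest and compound 2 furthest, both beyond the scatter. Compound 4 `CCOc1cc(C(c2c(O)c3cc(Cl)ccc3oc2=O)c2c(O)c3cc(Cl)ccc3oc2=O)ccc1O` is not yet measured; it arises from compound 1 by 3-ethoxy-4-hydroxyphenyl in place of 3-nitrophenyl on a saturated chain carbon bound to two aromatic carbons. Among the measured compounds shown here, no measured step swaps exactly this pair of aryl groups. For the measured compounds named here, the only measured step, a 1.7-fold lower number from compound 2 to compound 3 (0.24 log units; within the scatter), exchanges one oxygenated aryl for another on the methyl-bearing core and stays within the scatter, so it bears only loosely on the change here. The chlorine-bearing core of compound 1, absent from compounds 2 and 3, remains in place. For compound 4 a modest weakening is expected, a 2.2-fold higher number from compound 1 to compound 4 (0.35 log units; beyond the scatter), with wide uncertainty. Compound 4 is estimated at 60000 nM, ranging from 15000 nM to 250000 nM.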

Compound 4, half-maximal inhibitory concentration: 57100 nM
The estimate for compound 4 lay 1.1-fold (0.02 log units) above the measured number, and the stated range covers the measured number.
By their numbers in this assay, from the lowest: compound 1; then compound 4; then compounds 3 and 2 (each within the scatter of the next).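

Among the compounds shown here, on the core of compound 1, this assay gives the first direct reading of a nitrogen-free aryl replacing 3-nitrophenyl on a saturated chain carbon bound to two aromatic carbons, with a 2.1-fold higher number from compound 1 to compound 4 (0.32 log units; beyond the scatter) as the result. The earlier step stayed within the scatter, whereas this one shows that aryl exchange at this place can move the number beyond it, though only modestly. Nothing available accounts for this step.

Open, on these data alone, is how an aminophenyl or carboxyphenyl group would read on the same carbon. Also open, as far as these compounds go, is whether this exchange gives a similar step on the core of compound 3.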